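Swapping cyclopropyloxy for acetyl on an imidazoline agonist

This account rests on a few compounds, and the source may have more. Where it says the series, first, only, none or still open, it means among the compounds named here.

Measured so far:
- compound 1, `CCc1ccccc1OC(C)C1=NCCN1`: 100 nM
- compound 2, `CC(Oc1ccccc1OC1CC1)C1=NCCN1`: 47.9 nM
- compound 3, `C=COc1ccccc1OC(C)C1=NCCN1`: 631 nM

These values come from a functional assay on CHO cells for agonist activity at Alpha-2C adrenergic receptor (Homo sapiens); on this read-out higher numbers stand for an effect only at larger amounts of compound and lower numbers for an effect already at smaller amounts. Compound 2 gives the lowest number of the three; compound 1 sits nearest, compound 3 furthest. Compound 4, `CC(=O)c1ccccc1OC(C)C1=NCCN1`, is not yet measured; it differs from compound 2 by acetyl in place of cyclopropyloxy on an aromatic carbon. Among the measured compounds shown here, two steps bear on this. The change a 2.1-fold lower number from compound 1 to compound 2 (0.32 log units; beyond the scatter) shows the ring-bearing ether helps modestly, while a 13-fold higher number from compound 2 to compound 3 (1.12 log units; beyond the scatter) shows that trading the three-membered ring for a double-bond group costs a large amount. Acetyl also carries a double bond outside the aromatic ring, so a higher number is expected for compound 4, roughly a 6.3-fold higher number from compound 2 to compound 4 (0.80 log units; beyond the scatter). The estimate for compound 4 is 300 nM, within 60 nM to 1500 nM.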

Compound 4, half-maximal effective concentration: 200 nM
Compound 4: the middle estimate sits 1.5-fold (0.18 log units) above what was measured, and the stated range covers the measured number.
By their numbers in this assay, from the lowest: compound 2; then compounds 1 and 4 (each within the scatter of the next); then compound 3.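

In this assay, acetyl on this aromatic carbon cannot be told apart from ethyl (a 2.0-fold higher number from compound 1 to compound 4 (0.30 log units; within the scatter)). Replacing cyclopropyloxy with acetyl raises the number (a 4.2-fold higher number from compound 2 to compound 4 (0.62 log units; beyond the scatter)), whereas replacing vinyloxy with acetyl lowers it (a 3.2-fold lower number from compound 3 to compound 4 (0.50 log units; beyond the scatter)), so a double bond outside the aromatic ring does not always bring the number up to that of compound 3. Nothing measured here gives a reason for these steps. From the compounds shown here alone, whether an amine, a carboxylic acid or a longer ether chain on this carbon would match compound 2 remains open.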